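This account rests on a few compounds, and the source may have more. Where it says the series, first, only, none or still open, it means among the compounds named here.

Within the data shown here, in an ADME assay on microsomes from liver (Mus musculus) for metabolic stability, read by LC-MS, with a stated time of 30 min, tested at 1 uM (a lower number here means that less of the compound is left, a higher number that more of the compound is left), compound 2 `O=C(NCc1ccc(S(=O)(=O)c2cccc(C(F)(F)F)c2)cc1)c1cc2ccncc2o1` gives 64%, the highest of the three numbers so far. Compound 1 `O=C(NCc1ccc(S(=O)(=O)c2cccc(C(F)(F)F)c2)cc1)c1cc2cnccc2[nH]1` gives 49%, and compound 3 `O=C(NCc1ccc(S(=O)(=O)N2CCCCC2)cc1)c1cc2ccncc2o1` gives 0.14%. Compound 4 `O=C(NCc1ccc(S(=O)(=O)c2cccc(C(F)(F)F)c2)cc1)c1ccc2nccn2c1` is yet to be measured. It differs from compound 2 only on a carbonyl carbon whose other neighbour is an amide-type nitrogen: a group of 9 heavy atoms (7 carbon, 2 nitrogen; one five-membered aromatic ring with 2 hetero atoms, one six-membered aromatic ring with 1 hetero atom) in place of a group of 9 heavy atoms (7 carbon, 1 nitrogen, 1 oxygen; one five-membered aromatic ring with 1 hetero atom, one six-membered aromatic ring with 1 hetero atom), on a carbonyl carbon.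

One measured step falls at this same place: a number 15 percentage points higher from compound 1 to compound 2 (beyond the scatter), a modest change. The other, a number 63.9 percentage points lower from compound 2 to compound 3 (beyond the scatter), is large, but it concerns piperidin-1-yl and 3-(trifluoromethyl)phenyl on a sulfonyl sulfur, which compound 4 leaves as in compound 2, so it bears little on this change. The group entering compound 4 has 7 carbon and 2 nitrogen, as does the group in compound 1, which stands at 49%. The two groups still differ in their five-membered rings, so this single comparison is only a weak guide. A modest fall is expected, estimated as a number 12 percentage points lower from compound 2 to compound 4 (beyond the scatter). Compound 4 is expected to give 52%, within an estimated range of 30% to 72%.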

Compound 4, percent of the compound remaining: 17%
Beside the measured number, compound 4's estimate is 35 percentage points above it; the measured number lies below the stated range.
By their numbers in this assay, from the lowest: compound 3; then compound 4; then compound 1; then compound 2.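

Among these compounds, the result shows that in this assay the group on the carbonyl carbon can move the number by a large amount, with a number 47 percentage points lower from compound 2 to compound 4 (beyond the scatter) once the new group enters, whereas the only earlier step at this place was modest. A matching count of 7 carbon and 2 nitrogen does not keep the number level, with a number 32 percentage points lower from compound 1 to compound 4 (beyond the scatter) for two groups that differ in their five-membered rings, so the atom count of the group alone does not settle the outcome among these compounds. Nothing measured here accounts for this difference.

As far as these compounds go, whether piperidin-1-yl on the sulfonyl sulfur would give as large a step alongside the group in compound 4 remains open. Also open, from the compounds shown here alone, is where a simple phenyl or pyridin-3-yl group on the carbonyl carbon would stand in this assay.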